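The compounds below may be only part of what the source reports. "The series", "measured", "known", "first", "only" and "open" are said of these compounds alone.

Series notes. Two compounds share the core. Among the measured compounds shown here, compound 1 `CC1(C)CC12NC(=O)N(NC(=O)c1ccc(Br)cc1)C2=O` carries a 4-bromophenyl on the carbonyl; in a functional assay on the whole organism (Hindlimb) for inhibition, with Mus musculus as the target, with a stated time of 4 h (a lower number here means that less compound is needed, a higher number that more compound is needed for the effect), compound 1 gives 300 mg/kg, the highest of the two numbers so far. Compound 2 `CC1(C)CC12NC(=O)N(NC(=O)c1ccc(C(F)(F)F)cc1)C2=O` differs only by trifluoromethyl in place of bromo on an aromatic carbon, and compound 2 gives 30 mg/kg in this assay, a step of a 10-fold lower number from compound 1 to compound 2 (1.00 log units; beyond the scatter).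

Compound 3 `CC1(C)CC12NC(=O)N(NC(=O)c1ccco1)C2=O` is not yet measured. The change from compound 1 is furan-2-yl in place of 4-bromophenyl on a carbonyl carbon. For the measured compounds named here, no measured step concerns a swap of the aromatic ring itself; the one step in hand, from compound 1 to compound 2, changes only a substituent on the retained ring, so it gives no direction for this assay here. The expected step is therefore no change at the digits printed from compound 1 to compound 3 (within the scatter), within the scatter in either direction. For compound 3 the estimate in this assay is 300 mg/kg, with a range from 100 mg/kg to 1000 mg/kg.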

Compound 3, minimum effective dose: 300 mg/kg
Beside the measured number, compound 3's estimate shows no gap at the digits printed; the range from low to high includes it.
By their numbers in this assay, from the lowest: compound 2; then compounds 1 and 3 (each within the scatter of the next).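

Among the compounds shown here, the step of no change at the digits printed from compound 1 to compound 3 (within the scatter) in this assay is the first reading on a swap of the aromatic ring itself: on a carbonyl carbon whose other neighbour is an amide-type nitrogen, furan-2-yl and 4-bromophenyl are not told apart in this read-out. The number at this position therefore does not depend on a six-membered carbon ring, and a five-membered aromatic ring with a hetero atom serves equally here. No measured evidence bears on this result.

As far as these compounds go, whether trifluoromethyl on the furan-2-yl ring would repeat the step of a 10-fold lower number from compound 1 to compound 2 (1.00 log units; beyond the scatter) seen on the phenyl ring remains open. Also open, from the compounds shown here alone, is how a non-aromatic group on the same carbonyl carbon, such as cyclohexyl or a longer alkyl chain, would read in this assay.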